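Diethylamino in Place of a Bicyclic Amine on the Core

The source may report more compounds than this note shows. Statements on the series, on what has been measured and on what is new or still open speak of the compounds shown alone.

Compound 2 `O=C(CCc1ccc(C(F)(F)F)cc1)Nc1ccc2nc(N3CC4CC3CO4)ccc2c1` has been measured in an assay on isolated protein for displacement of a labelled ligand from melanin-concentrating hormone receptor 1 (Homo sapiens) (on this read-out higher numbers stand for weaker inhibition and lower numbers for stronger inhibition), where compound 2 gives 13 nM. Its nearest measured neighbour is compound 1 `CN(C)c1ccc2cc(NC(=O)CCc3ccc(C(F)(F)F)cc3)ccc2n1`, and in this assay compound 1 gives 13 nM, so compound 2 stands level with compound 1 within the scatter. Within the data shown here, the only step measured so far, no change at the digits printed from compound 1 to compound 2 (within the scatter), exchanged a dimethylamino group for the bicyclic group that compound 2 carries, and it produced no change beyond the scatter.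

Compound 3 `CCN(CC)c1ccc2cc(NC(=O)CCc3ccc(C(F)(F)F)cc3)ccc2n1` is not yet measured. It differs from compound 2 by a group of 5 heavy atoms (4 carbon, 1 nitrogen; no ring) in place of a group of 7 heavy atoms (5 carbon, 1 nitrogen, 1 oxygen; 2 five-membered non-aromatic rings with 1 hetero atom each), on an aromatic carbon. The change puts a small open-chain amine back on the aromatic carbon next to the ring nitrogen, much as in compound 1, and the measured step bearing on it ran the other way between the same kinds of groups. Because no change at the digits printed from compound 1 to compound 2 (within the scatter) showed no change, compound 3 is expected to remain close, with no change at the digits printed from compound 2 to compound 3 (within the scatter) meaning no step beyond the scatter. The estimate for compound 3 in this assay is 13 nM, with a range from 5 nM to 40 nM.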

Compound 3, half-maximal inhibitory concentration: 88 nM
Estimate against measurement, compound 3: 6.8-fold (0.83 log units) below; the measured number lies above the stated range.
By their numbers in this assay, from the lowest: compounds 1 and 2 (each within the scatter of the next); then compound 3.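

In this assay, among these compounds, the step to diethylamino shows that this position, on an aromatic carbon next to the ring nitrogen, does respond to the amine it carries: the change of dimethylamino to diethylamino gives a 6.8-fold higher number from compound 1 to compound 3 (0.83 log units; beyond the scatter), a difference that the first pair of compounds gave no sign of. The second step, a 6.8-fold higher number from compound 2 to compound 3 (0.83 log units; beyond the scatter), shows that the heavy-atom count of the group does not order these three compounds, since compound 2 carries the largest group and stands level with compound 1, while compound 3, with a group of intermediate count, has the highest number. Nothing available here speaks to why diethylamino parts from the other two groups.

On these data alone, it remains open whether a single-ring amine such as pyrrolidine or morpholine, or an open-chain ethylmethylamino group, would stand with compounds 1 and 2 or with compound 3. As far as these compounds go, it is also open whether the step from dimethylamino to diethylamino would keep its size if the trifluoromethyl group on the far aromatic ring were replaced by a chlorine atom or a nitrile.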